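The source may hold more compounds than are shown below. What is called first, only, known or untested is meant among the compounds shown, and "the series" means these compounds.

Of the compounds shown here, three sharing one core have been tested in a functional assay on MCF7 cells (Homo sapiens) for inhibition, read by MTT assay, with a stated time of 48 h, tested at 10 uM; on this read-out higher numbers stand for more inhibition of growth at the one concentration tested and lower numbers for less inhibition of growth. Compound 1 (`COc1ccc(COc2cc(O)c3c(=O)cc(C)oc3c2[C@H]2CCN(C)C[C@H]2O)cc1`) gives 16%, compound 2 (`Cc1cc(=O)c2c(O)cc(O)c([C@H]3CCN(C)C[C@H]3OC(=O)c3ccco3)c2o1`) gives 20% and compound 3 (`Cc1oc2c([C@H]3CCN(C)C[C@H]3O)c(O)cc(O)c2c(=O)c1C(O)c1ccc([N+](=O)[O-])cc1`) gives 4%. Compound 3 therefore stands lowest of the three, and the values of the other two lie above it by more than the usual scatter, with compound 1 the nearer.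

Compound 4 (`Cc1oc2c([C@H]3CCN(C)C[C@H]3O)c(O)cc(O)c2c(=O)c1C(O)c1c(Cl)cccc1Cl`) has not yet been measured in this assay. It carries 2,6-dichlorophenyl in place of 4-nitrophenyl on a saturated chain carbon bound to an aromatic carbon and an oxygen on a saturated carbon. Among the compounds with values here, no measured pair shows this exchange, so the expectation rests on little. All three values are low, and compound 3 at 4% sits near the bottom of the scale, which leaves more room for a rise than for a fall. Compound 2 at 20% marks the top of what this small set has shown so far.

A small upward step of about the size of the scatter is expected, a number 9 percentage points higher from compound 3 to compound 4 (within the scatter). For compound 4 the estimated value is 13%, with an expected range from 0% to 30%.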

Compound 4, percent growth inhibition at one concentration: 33%
For compound 4 the middle estimate is 20 percentage points below the measured one; the whole stated range lies below it.
By their numbers in this assay, from the lowest: compound 3; then compounds 1 and 2 (each within the scatter of the next); then compound 4.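

In this assay, within the data shown here, putting 2,6-dichlorophenyl in place of 4-nitrophenyl on a saturated chain carbon bound to an aromatic carbon and an oxygen on a saturated carbon gives a number 29 percentage points higher from compound 3 to compound 4 (beyond the scatter), the first step in this set that can be read at this place. It shows that the read-out responds to the aryl group carried on this carbon, and that the low number of compound 3 does not hold for every aryl group there. The exchange alters several things at once, since 4-nitrophenyl leaves with its nitrogen and oxygen atoms and 2,6-dichlorophenyl enters with its chlorine atoms, so this one step cannot say whether the loss of the first group or the arrival of the second accounts for it.

Going by these compounds, whether a plain phenyl, a 4-chlorophenyl or a 4-aminophenyl on the same carbon would read nearer to compound 3 or to compound 4 stays open. What lies behind the step also stays open, as no evidence at hand bears on it.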